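The compounds below may be only part of what the source reports. "The series", "measured", "known", "first", "only" and "open" are said of these compounds alone.

Measured compounds:
- compound 1, `O=C(Nc1c(C(O)(C(F)(F)F)C(F)(F)F)ccc2ccccc12)C1CCC1`, in an assay on LtK cells with ATP-sensitive inward rectifier potassium channel 11 (Homo sapiens) as the target; a lower number here means that less compound is needed, a higher number that more compound is needed for the effect: 45 nM
- compound 2, `N#Cc1cccc(C(=O)Nc2c(C(O)(C(F)(F)F)C(F)(F)F)ccc3ccccc23)c1`, in this assay: 12 nM

Compound 2 stands with the lowest of the two numbers recorded so far. Among the measured compounds shown here, its nearest neighbour is compound 1, and the one measured step, a 3.8-fold lower number from compound 1 to compound 2 (0.57 log units; beyond the scatter), shows that replacing cyclobutyl with 3-cyanophenyl on the carbonyl carbon lowered the number by a modest amount that lies beyond the usual scatter.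

Compound 3, `O=C(Nc1c(C(O)(C(F)(F)F)C(F)(F)F)ccc2ccccc12)c1ccc(Cl)c(Cl)c1`, has not yet been measured in this assay. It differs from compound 2 in one place: 3,4-dichlorophenyl in place of 3-cyanophenyl on a carbonyl carbon. For the measured compounds named here, both compound 2 and compound 3 carry a six-membered aromatic ring of carbon only on the carbonyl carbon, so the only measured step, which swapped a saturated ring for an aromatic one, bears on this change only loosely. Going by the values given here, no measured pair shows what exchanging one substituted phenyl for another does here. With nothing pointing clearly in either direction, compound 3 is expected to land close to compound 2, with no change at the digits printed from compound 2 to compound 3 (within the scatter) not exceeding the scatter. The estimate for compound 3 in this assay is 12 nM, with a range from 4 nM to 40 nM.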

Compound 3, half-maximal effective concentration: 194 nM
Compound 3: middle estimate off by 16-fold (1.21 log units), on the low side; measured number above the stated range.
By their numbers in this assay, from the lowest: compound 2; then compound 1; then compound 3.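

In this assay, the choice of substituents on the aromatic ring on the carbonyl carbon turns out to matter a great deal: swapping 3-cyanophenyl for 3,4-dichlorophenyl gives a 16-fold higher number from compound 2 to compound 3 (1.21 log units; beyond the scatter) even though both groups hold one six-membered aromatic ring and the same count of heavy atoms. An aromatic ring at this place therefore does not by itself lower the number, since replacing cyclobutyl with 3,4-dichlorophenyl gives a 4.3-fold higher number from compound 1 to compound 3 (0.63 log units; beyond the scatter) and so runs opposite to the earlier move from cyclobutyl to 3-cyanophenyl. Nothing in the available data explains why these two aromatic groups differ so strongly here.

Going by these compounds, with only these three compounds, it remains open whether the nitrile helps, the two chlorines hurt, or both effects contribute, and a plain phenyl group at this place would help separate these possibilities. On these data alone, it is also open how a single chlorine, a methoxy group or an amine on the phenyl ring would shift the number, so no trend across substituents can yet be drawn.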